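Amide-side variation on the shared core: first calcium-flux comparison

The compounds below may be only part of what the source reports. "The series", "measured", "known", "first", "only" and "open" are said of these compounds alone.

Measured so far:
compound 1 `CCCC(=O)N1CC2CC(C1)N2` — 580 nM
compound 2 `O=C(CC1C=CCC1)N1CC2CC(C1)N2` — 14000 nM

In an assay on SH-EP1 cells for agonist activity at Neuronal acetylcholine receptor; alpha4/beta2 (Homo sapiens), read by FLIPR and calcium flux (on this read-out lower numbers stand for an effect already at smaller amounts and higher numbers for an effect only at larger amounts of compound), compound 1 gives 580 nM, the lowest of the two numbers; compound 2 gives 14000 nM, and the step of a 24-fold higher number from compound 1 to compound 2 (1.38 log units; beyond the scatter) is large. Compound 3 `O=C([C@H]1C[C@H]1F)N1CC2CC(C1)N2` carries 2-fluorocyclopropyl in place of propyl on a carbonyl carbon. Among the measured compounds shown here, only the step from compound 1 to compound 2 bears on this change, and it concerns a different group entering, so it guides only loosely. The one-ring replacement in compound 3 is closer in heavy-atom count to propyl than cyclopent-2-en-1-yl was, so a smaller shift is expected. For compound 3 the estimate is 1000 nM (range 300 nM to 4000 nM), meaning an expected step of a 1.7-fold higher number from compound 1 to compound 3 (0.24 log units; within the scatter).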

Compound 3, half-maximal effective concentration: 210 nM
The estimate for compound 3 lay 4.8-fold (0.68 log units) above the measured number; the measured number lies below the stated range.
By their numbers in this assay, from the lowest: compound 3; then compound 1; then compound 2.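

On the carbonyl carbon, 2-fluorocyclopropyl in place of propyl gives in this assay a 2.8-fold lower number from compound 1 to compound 3 (0.44 log units; beyond the scatter), so a group with a ring at this place can lower the number. Among the compounds shown here, the only earlier step, a 24-fold higher number from compound 1 to compound 2 (1.38 log units; beyond the scatter), with cyclopent-2-en-1-yl entering on the chain, went the other way, so a ring in the acyl group does not by itself raise the number. No supporting data bear on this result.

Open: how plain cyclopropyl, without fluorine, would read at this carbonyl carbon. The step therefore cannot yet be divided between the ring and the fluorine.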